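Notes on the step from compound 3 to compound 4

The compounds below may be only part of what the source reports. "The series", "measured", "known", "first", "only" and "open" are said of these compounds alone.

Measured in an ADME assay on NCM460 cells (Homo sapiens) for cytotoxicity, read by CCK-8 assay, with a stated time of 48 h; on this read-out lower numbers stand for stronger inhibition and higher numbers for weaker inhibition:
- compound 1 `COc1ccc(/C=C\c2cc(OC)c(OC)c(OC)c2)cc1OCc1ccc(C=O)cc1`: 41000 nM
- compound 2 `COc1ccc(/C=C\c2cc(OC)c(OC)c(OC)c2)cc1OCc1ccc(CN2CCCC[C@@H]2C(=O)O)cc1`: > 50000 nM, a limit of the assay
- compound 3 `COc1ccc(/C=C\c2cc(OC)c(OC)c(OC)c2)cc1OCc1ccc(CNCCO)cc1`: 39000 nM

Compound 3, at 39000 nM, lies within the scatter of compound 1. Compound 2 sits at the limit of > 50000 nM in this assay, at which 1 of the 3 values shown sits, which is a limit.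

The next structure is compound 4 `COc1ccc(/C=C\c2cc(OC)c(OC)c(OC)c2)cc1OCc1ccc(CN2CC[C@H](C(=O)O)C2)cc1`. The change is 3-carboxypyrrolidin-1-yl in place of (2-hydroxyethyl)amino on a saturated chain carbon bound to an aromatic carbon.

The closest measured change runs the other way, from 2-carboxypiperidin-1-yl to (2-hydroxyethyl)amino, and it gave an at least 1.2-fold lower number from compound 2 to compound 3 (0.10 log units; that floor lies within the scatter). Replacing formyl gave an at least 1.2-fold higher number from compound 1 to compound 2 (0.08 log units; that floor lies within the scatter) and a 1.1-fold lower number from compound 1 to compound 3 (0.02 log units; within the scatter). None of these steps leaves the scatter, so no step beyond the scatter is expected in this assay, with a slight lean towards higher numbers from compound 2.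

The expected step is a 1.3-fold higher number from compound 3 to compound 4 (0.11 log units; within the scatter).

For compound 4 the estimated value is 50000 nM, with an expected range of 33000 nM to 90000 nM.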

Compound 4, half-maximal inhibitory concentration: > 50000 nM
Compound 4 was reported as a limit; the forecaster's own chance of this, stated with the estimate: 60%; the middle value sits exactly at the limit.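

Compound 4 is a limit in this assay, so the 3-carboxypyrrolidin-1-yl group of compound 4 and the 2-carboxypiperidin-1-yl group of compound 2 both end at the same limit: the limit of > 50000 nM in this assay, at which 2 of the 4 values shown sit. From the compounds shown here alone, the readable steps, an at least 1.2-fold higher number from compound 3 to compound 4 (0.10 log units; that floor lies within the scatter) and an at least 1.2-fold higher number from compound 1 to compound 4 (0.08 log units; that floor lies within the scatter), have floors within the scatter, so this change on the saturated chain carbon establishes no step beyond the scatter, though the true size remains unknown. The step from compound 2 to compound 4 cannot be read, and the two carboxylated rings cannot be ordered.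

Going by these compounds, whether the carboxylic acid or the ring goes with the limit stays open. An unsubstituted pyrrolidin-1-yl group, or a longer chain ending in a carboxylic acid, on the same carbon would help separate the two.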